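Trimming the Oxime Substituent in a Fluorinated Sulfide Series

The source may report more compounds than this note shows. Statements on the series, on what has been measured and on what is new or still open speak of the compounds shown alone.

Of the compounds shown here, three have been measured in a functional assay (blood) for inhibition, with Homo sapiens as the target; on this read-out lower numbers stand for stronger inhibition and higher numbers for weaker inhibition. Compound 1 `CO[C@]1(c2cc(F)cc(S(=O)(=O)c3ccc(/C(C)=N/O)cc3)c2)CCO[C@@H](C)C1` gives 20 nM, compound 3 `CO[C@]1(c2cnc(Sc3ccc(/C(C)=N/O)cc3)s2)CCO[C@@H](C)C1` gives 40 nM, and compound 2 `CN(C)/C(=N\O)c1ccc(Sc2cc(F)cc(C3CCOCC3)c2)cc1` gives 280 nM, the highest of the three numbers and beyond the scatter from both others. Compound 4 `C/C(=N\O)c1ccc(Sc2cc(F)cc(C3CCOCC3)c2)cc1` has not yet been measured. It differs from compound 2 by methyl in place of dimethylamino on a carbon with a double bond to nitrogen. Going by the values given here, no measured pair shows exactly this change, but compound 1 and compound 3, which both carry methyl on the carbon with a double bond to nitrogen, give far lower numbers than compound 2. On that basis the expected step of a 4.7-fold lower number from compound 2 to compound 4 (0.67 log units; beyond the scatter) points toward stronger inhibition, beyond the scatter. Compound 4 is therefore estimated at 60 nM in this assay, with a range from 20 nM to 200 nM.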

Compound 4, half-maximal inhibitory concentration: 80 nM
Compound 4: the middle estimate sits 1.3-fold (0.12 log units) below what was measured; low and high end bracket the measured number.
By their numbers in this assay, from the lowest: compounds 1, 3 and 4 (each within the scatter of the next, the first and the last beyond it); then compound 2.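

In this assay, going by these compounds alone, this pair isolates the change for the first time, giving a 3.5-fold lower number from compound 2 to compound 4 (0.54 log units; beyond the scatter) for methyl in place of dimethylamino on a carbon with a double bond to nitrogen. Within the data shown here, the step is modest but beyond the scatter, and the rest of the molecule is identical, whereas the earlier compounds differed in several places at once. Still open, going by these compounds, is how an ethyl chain or a primary amine on that carbon would compare, and whether the step carries over to the cores of compound 1 and compound 3. No evidence at hand bears on what lies behind this step.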